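Step from compound 3 to compound 4 in the shared series

The source may report more compounds than this note shows. Statements on the series, on what has been measured and on what is new or still open speak of the compounds shown alone.

In a functional assay on CWR22R cells (Homo sapiens) for antiproliferative activity, read by CCK-8 assay, with a stated time of 6 days (on this read-out higher numbers stand for weaker inhibition and lower numbers for stronger inhibition), compound 1 `CC(O)c1cccc(C(=O)N[C@@H](C)Cn2ccc(-c3ccc(C#N)c(Cl)c3)n2)c1` gives 20100 nM. In this assay compound 2 `COc1ccc(C(=O)N[C@@H](C)Cn2ccc(-c3ccc(C#N)c(Cl)c3)n2)cc1` gives "not determined" (no result reported), and compound 3 `COC(=O)/C=C/C(=O)N[C@@H](C)Cn1ccc(-c2ccc(C#N)c(Cl)c2)n1` gives "not determined" (no result reported). Compound 3 therefore stands without a single number on this read-out, and one further entry, compound 2, is in the same position; only compound 1 carries a value, and it is a weak one. Compound 4 `C[C@@H](Cn1ccc(-c2ccc(C#N)c(Cl)c2)n1)Nc1ncnc2nc[nH]c12` is not yet measured. It differs from compound 3 by a group of 9 heavy atoms (5 carbon, 4 nitrogen; one five-membered aromatic ring with 2 hetero atoms, one six-membered aromatic ring with 2 hetero atoms) in place of a group of 8 heavy atoms (5 carbon, 3 oxygen; no ring), on an amine nitrogen. Going by the values given here, no step between measured compounds is known, so the size of the step from compound 3 to compound 4 in this assay cannot be set from the series; a direction is not fixed either, and a change no larger than the usual scatter is as plausible as a gain. The expectation for compound 4 rests on compound 1 with 20100 nM. Compound 4 is estimated at 10000 nM, range 2000 nM to 40000 nM.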

Compound 4, half-maximal inhibitory concentration: 4240 nM
Beside the measured number, compound 4's estimate is 2.4-fold (0.37 log units) above it; measured number inside the range.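

Going by these compounds alone, compound 3 has no single number in this assay, so no step from it to compound 4 can be read. Nothing available explains the result of compound 4. The compounds shown leave open how the two groups on the amine nitrogen compare.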